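The source may report more compounds than this note shows. Statements on the series, on what has been measured and on what is new or still open speak of the compounds shown alone.

The compounds measured so far in an ADME assay on Caco-2 cells (Homo sapiens) for permeability, in the apical to basolateral direction (on this read-out higher numbers stand for higher permeability and lower numbers for lower permeability), are these three, each with the value it gave:

Compound 1, `CNC(=O)c1cc(Oc2ccc3nc(Nc4cccc(C(C)(C)C)c4)cnc3c2)ccn1`: compound 1 gives < 1 10^-6 cm/s, a limit of the assay and not a number.
Compound 2, `CNC(=O)c1cc(Oc2ccc3nc(Nc4ccccc4Oc4ccccc4)ncc3c2)ccn1`: compound 2 gives < 1 10^-6 cm/s, again a limit and not a number.
Compound 3, `CNC(=O)c1cc(Oc2ccc3nc(Nc4cccc(Cl)c4)ncc3c2)ccn1`: compound 3 gives < 1 10^-6 cm/s, once more a limit and not a number.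

Compound 3 therefore stands nowhere in particular on the numbers shown, since its reading is only a limit, and the same holds for the other two compounds; all three sit at the limit of < 1 10^-6 cm/s in this assay, at which 3 of the 3 values shown sit, so no step between measured compounds can be counted and no ordering among them can be drawn.

The unmeasured compound 4, `CNC(=O)c1cc(Oc2ccc3nc(Nc4ccc(F)cc4)ncc3c2)ccn1`, differs from compound 3 in one place: 4-fluorophenyl in place of 3-chlorophenyl on a nitrogen on an aromatic ring. With every measured compound at the limit, nothing in the data points to a step in either direction beyond the usual scatter of this assay; the change is a small exchange on one phenyl ring while the shared core and the rest of the molecule stay the same.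

Compound 4 is therefore expected to stay close to the limit as well, with an estimated value of 0.7 10^-6 cm/s, likely falling between 0.2 10^-6 cm/s and 2.5 10^-6 cm/s. The step from compound 3 to compound 4 that this estimate means, a step that the limit leaves unreadable from compound 3 to compound 4, is expected to lie within the scatter, with a fair chance that the assay again reports only a limit.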

Compound 4, apparent permeability: < 1 10^-6 cm/s
Compound 4 gave a limit, no number; the forecaster's own chance of this, stated with the estimate: 70%; the middle value is on the limit's open side.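

In this assay, compound 4 gives < 1 10^-6 cm/s, a limit of the assay and not a number. Compound 3 also gives only a limit, so no step between compound 3 and compound 4 can be read, and every compound shown sits at the same limit: the limit of < 1 10^-6 cm/s in this assay, at which 4 of the 4 values shown sit.

The compounds shown leave open what actual permeability value each would have, and so whether 4-fluorophenyl and 3-chlorophenyl differ at all on this read-out.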